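Replacing the Amide Chain with a Sulfamoylphenyl Group

A few compounds are considered here, and "the series" means these few. Any claim that something is new, unique, unknown or untested is made for them only; others in the source may bear on it.

Among the measured compounds shown here, compound 2 `CCOc1nc2cccc(C(=O)NCCCN(C)C)c2n1Cc1ccc(-c2ccccc2-c2nnn[nH]2)cc1` is one of two compounds measured in an assay on isolated protein for inhibition of NEDD8-activating enzyme E1 regulatory subunit (Homo sapiens), read by Western blot, with stated times of 10 min and 30 min, tested at 25 uM (a higher number here means more inhibition at the concentration tested (going by the name of the read-out), a lower number less inhibition), where compound 2 gives 29.5%. Compound 1 `CCCNC(=O)c1cccc2nc(OCC)n(Cc3ccc(-c4ccccc4-c4nnn[nH]4)cc3)c12` gives 32.6% in this assay, and the gap a number 3.1 percentage points lower from compound 1 to compound 2 (within the scatter) is within the scatter, so neither compound stands apart from the other. Compound 3 `CCOc1nc2cccc(C(=O)Nc3ccc(S(N)(=O)=O)cc3)c2n1Cc1ccc(-c2ccccc2-c2nnn[nH]2)cc1` differs from compound 2 by 4-sulfamoylphenyl in place of 3-(dimethylamino)propyl on an amide-type nitrogen. For the measured compounds named here, the only measured step, a number 3.1 percentage points lower from compound 1 to compound 2 (within the scatter), concerns the same amide-type nitrogen, but it adds a dimethylamino group to the chain rather than exchanging the chain for an aromatic ring, and it stayed within the scatter; it therefore gives no direction for a change of this size. Going by the values given here, with no measured step pointing up or down, compound 3 is expected to remain near the measured pair in this assay, at an estimated 30%, with a range from 12% to 50%. This estimate means an expected step of a number 0.5 percentage points higher from compound 2 to compound 3 (within the scatter).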

Compound 3, a percentage reported as inhibition, at one concentration (the size of the read-out at that concentration, not a potency): 60.9%
Compound 3: the middle estimate sits 30.9 percentage points below what was measured; the whole stated range lies below it.
By their numbers in this assay, from the lowest: compounds 2 and 1 (each within the scatter of the next); then compound 3.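

At the amide-type nitrogen, exchanging an open chain for 4-sulfamoylphenyl moves the read-out in this assay clearly, with a number 31.4 percentage points higher from compound 2 to compound 3 (beyond the scatter) and a number 28.3 percentage points higher from compound 1 to compound 3 (beyond the scatter). Among the compounds shown here, the earlier change at this nitrogen, which added dimethylamino to the chain, had stayed within the scatter, so these are the first steps to show that the group on this nitrogen can alter inhibition, and the rise appears from both chains. Nothing available explains the rise.

The compounds shown leave open whether the aromatic ring or the sulfamoyl group carries the step, a question that a plain phenyl group, or a phenyl ring bearing a carboxylic acid, on this nitrogen would address. They also leave open how compound 3 ranks by potency, as each number is a reading at one concentration.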